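Methoxy in Place of Chloro on the Anilide Ring

The source may hold more compounds than are shown below. What is called first, only, known or untested is meant among the compounds shown, and "the series" means these compounds.

The measured compounds are:
compound 1, `O=C(CSc1nc(Nc2ccccc2)c2ccccc2n1)Nc1ccccc1Cl`, 24400 nM
compound 2, `O=C(CSc1nc(Nc2ccccc2)c2ccccc2n1)Nc1ccccc1Br`, 14100 nM
compound 3, `O=C(CSc1nc(Nc2ccccc2)c2ccccc2n1)Nc1cccc(Cl)c1`, 16500 nM

All three share one core and differ only in the substituent on the anilide ring. In a functional assay on MDA-MB-231 cells (Homo sapiens) for inhibition, read by MTT assay, with a stated time of 72 h (on this read-out higher numbers stand for weaker inhibition and lower numbers for stronger inhibition), compound 1 gives 24400 nM, compound 2 gives 14100 nM and compound 3 gives 16500 nM. Compound 3 sits between the other two on these numbers: the gap a 1.5-fold lower number from compound 1 to compound 3 (0.17 log units; within the scatter) and the gap a 1.2-fold higher number from compound 2 to compound 3 (0.07 log units; within the scatter) are both within the scatter, so nothing separates the three beyond noise.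

Compound 4, `COc1cccc(NC(=O)CSc2nc(Nc3ccccc3)c3ccccc3n2)c1`, is unmeasured. It differs from compound 3 by methoxy in place of chloro on an aromatic carbon. The relevant precedents are the halogen swap a 1.7-fold lower number from compound 1 to compound 2 (0.24 log units; within the scatter) and the position changes a 1.5-fold lower number from compound 1 to compound 3 (0.17 log units; within the scatter) and a 1.2-fold higher number from compound 2 to compound 3 (0.07 log units; within the scatter), every one within the scatter. For the measured compounds named here, no measured pair probes a methoxy group, so the change is partly uncharted, but the series so far has been indifferent to what sits on this ring. The account therefore expects no step beyond the scatter in this assay for compound 4, that is a 1.2-fold higher number from compound 3 to compound 4 (0.08 log units; within the scatter). Compound 4 is estimated at 20000 nM, with a range from 8000 nM to 50000 nM.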

Compound 4, half-maximal inhibitory concentration: 21700 nM
Beside the measured number, compound 4's estimate is 1.1-fold (0.04 log units) below it; the range from low to high includes it.
By their numbers in this assay, from the lowest: compounds 2, 3, 4 and 1 (each within the scatter of the next).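

In this assay the step of a 1.3-fold higher number from compound 3 to compound 4 (0.12 log units; within the scatter) is the only one here that replaces a halogen with a group holding oxygen, methoxy bringing one hydrogen-bond acceptor where chloro brought none, and it stays within the scatter, so this carbon of the anilide ring tolerates more than a swap among halogens. The steps of a 1.5-fold higher number from compound 2 to compound 4 (0.19 log units; within the scatter) and a 1.1-fold lower number from compound 1 to compound 4 (0.05 log units; within the scatter) change both the group and its place on the ring, and they too stay within the scatter, so none of the four compounds stands apart from the others and no preference for a group or a position can be read from them. No measurement at hand offers an explanation for this flat response.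

The compounds shown leave open whether an amine, a carboxylic acid or a longer alkoxy chain on this ring would move the number beyond the scatter, since every group seen so far is a halogen or methoxy. On these data alone, the rest of the shared core is identical in all four compounds, so what a change there would do also remains unknown.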